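This account rests on a few compounds, and the source may have more. Where it says the series, first, only, none or still open, it means among the compounds named here.

Compound 1 `C(=C/c1[nH]cnc2ncnc1-2)\c1ccsc1`: 32%. Compound 2 `COC(=O)/C(C)=C/C=C/c1[nH]cnc2ncnc1-2`: 20%.

In a functional assay on K562 cells (Homo sapiens) for inhibition, read by thymidine incorporation, with a stated time of 48 h, tested at 10 ug/mL (a lower number here means less inhibition, a higher number more inhibition at the concentration tested (going by the name of the read-out)), compound 2 gives the lower of these two numbers, and the gap to compound 1 lies beyond the usual scatter. Compound 3 `C/C(=C\C=C\c1[nH]cnc2ncnc1-2)CO` has not yet been measured in this assay. It differs from compound 2 in one place: hydroxymethyl in place of methoxycarbonyl on a double-bonded chain carbon bound to a double-bonded chain carbon and a saturated chain carbon. Among the compounds with values here, no measured pair shows what this exchange does here, so there is no basis for a sizeable shift in either direction, and the expected step is a number 2 percentage points higher from compound 2 to compound 3 (within the scatter), within the scatter. Compound 3 is estimated at 22%, with a range from 5% to 45%.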

Compound 3, a percentage reported as inhibition, at one concentration (the size of the read-out at that concentration, not a potency): 6%
Estimate against measurement, compound 3: 16 percentage points above, within the range that was stated.
By their numbers in this assay, from the lowest: compound 3; then compound 2; then compound 1.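

Putting hydroxymethyl in place of methoxycarbonyl on a double-bonded chain carbon bound to a double-bonded chain carbon and a saturated chain carbon gives a number 14 percentage points lower from compound 2 to compound 3 (beyond the scatter) in this assay, so the group at this position does change the inhibition seen. With 2-(hydroxymethyl)prop-1-en-1-yl in place of thiophen-3-yl, the step is a number 26 percentage points lower from compound 1 to compound 3 (beyond the scatter), which leaves compound 3 lowest of the three. No outside measurement accounts for either step.

Going by these compounds, how a carboxylic acid or an amine on this carbon would compare remains open.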